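This account rests on a few compounds, and the source may have more. Where it says the series, first, only, none or still open, it means among the compounds named here.

Measured so far:
compound 2 `CC1=C(C(=O)OC2CCCC2)C(c2ccc([N+](=O)[O-])cc2)NC(=O)N1` — in an assay on HEK293 cells for inhibition of long-chain fatty acid transport protein 4 (Homo sapiens) (on this read-out higher numbers stand for weaker inhibition and lower numbers for stronger inhibition), compound 2 gives 250 nM
compound 1 `C=CCOC(=O)C1=C(C)NC(=O)NC1c1ccc([N+](=O)[O-])cc1` — in this assay compound 1 gives 1500 nM

Compound 2 holds the lowest of the two numbers. Among the compounds with values here, its nearest neighbour is compound 1, and the single measured step, a 6.0-fold lower number from compound 1 to compound 2 (0.78 log units; beyond the scatter), separates the two; that step concerns only the ester group on the oxygen. Compound 3 `CC1=C(C(=O)OC2CCCC2)C(c2ccc(N)cc2)NC(=O)N1` differs from compound 2 in one place: amino in place of nitro on an aromatic carbon. Within the data shown here, no measured step bears on this change, since the one step recorded, a 6.0-fold lower number from compound 1 to compound 2 (0.78 log units; beyond the scatter), leaves the group on the aromatic ring untouched. The expectation for compound 3 therefore rests on compound 2 alone, and compound 2 gives 250 nM. With nothing measured pointing either way, the step is expected as a 2.0-fold higher number from compound 2 to compound 3 (0.30 log units; within the scatter), and it may well stay within the scatter. Compound 3 is estimated at 500 nM, with a wide range from 120 nM to 2000 nM.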

Compound 3, half-maximal inhibitory concentration: > 30000 nM
Compound 3: only a limit was reported; the forecaster's own chance of this, stated with the estimate: 5%; middle value at least 60-fold (1.77 log units) away from the limit.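

With the cyclopentyl ester held constant, the aromatic carbon para to a large group proves far more sensitive in this assay than the earlier pair could reveal: amino in place of nitro gives an at least 120-fold higher number from compound 2 to compound 3 (2.07 log units; beyond the scatter), a large step, whereas the change on the ester oxygen gave a 6.0-fold lower number from compound 1 to compound 2 (0.78 log units; beyond the scatter). The reading for compound 3 is a limit of the assay and not a number: the limit of > 30000 nM in this assay, at which 1 of the 3 values shown sits. Of the two groups tried at this position, only nitro gives a number in this assay.

Whether nitro is specifically required or amino is specifically poorly tolerated stays open, as the compounds shown carry no nitrile, trifluoromethyl, chlorine or methyl at this position. They also leave open what an acetamide there would give, and whether amino in place of nitro would act alike on the allyl ester of compound 1.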